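This account rests on a few compounds, and the source may have more. Where it says the series, first, only, none or still open, it means among the compounds named here.

Two compounds of this small set share the same core and carry a benzyl-type group on a triazole. Compound 1 `COc1ccc([C@@H]2CC(=O)c3c(O)cc(OCc4cn(Cc5cccc(C#N)c5)nn4)cc3O2)cc1O` bears a 3-cyanobenzyl group there, while compound 2 `COc1ccc([C@@H]2C/C(=N\O)c3c(O)cc(OCc4cn(Cc5ccccc5Cl)nn4)cc3O2)cc1O` bears a 2-chlorobenzyl group and also differs at the carbonyl, which is replaced by an oxime. Among the measured compounds shown here, in a functional assay on RAW264.7 cells (Mus musculus) for inhibition, read by Griess assay, with stated times of 2 h and 24 h (on this read-out lower numbers stand for stronger inhibition and higher numbers for weaker inhibition), compound 1 gives 18000 nM, and compound 2 gives 13400 nM; the two values lie within the scatter of each other, so neither compound can be set apart on these numbers, and no single-change step links them.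

Compound 3 `COc1ccc([C@@H]2CC(=O)c3c(O)cc(OCc4cn(CCCO)nn4)cc3O2)cc1O` keeps the carbonyl of compound 1 and changes only the group on the triazole: 2-hydroxyethyl in place of 3-cyanophenyl on a saturated chain carbon bound to an aromatic nitrogen. An aromatic ring with a nitrile thus gives way to a short chain carrying a hydroxyl. For the measured compounds named here, no measured step of this kind is available, so the expected size of the change rests on the structures alone. A modest weakening is expected, meaning a somewhat higher number, though one that may well stay within the scatter. Compound 3 is therefore estimated to give 25000 nM, in a range from 10000 nM to 60000 nM. The expected step of a 1.4-fold higher number from compound 1 to compound 3 (0.14 log units; within the scatter) is thus small and uncertain.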

Compound 3, half-maximal inhibitory concentration: 16700 nM
Beside the measured number, compound 3's estimate is 1.5-fold (0.18 log units) above it, and the stated range covers the measured number.
By their numbers in this assay, from the lowest: compounds 2, 3 and 1 (each within the scatter of the next).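

Among the compounds shown here, this is the first comparison here that differs in one place only. In this assay, putting 2-hydroxyethyl in place of 3-cyanophenyl on a saturated chain carbon bound to an aromatic nitrogen gives a 1.1-fold lower number from compound 1 to compound 3 (0.03 log units; within the scatter). For this pair, then, a group of 8 heavy atoms with an aromatic ring and a nitrile and a group of 3 heavy atoms with no ring and a hydrogen-bond donor give numbers that cannot be told apart, and nothing available accounts for this.

As far as these compounds go, it remains open whether an amine, a carboxylic acid or a longer chain in this place would give a number beyond the scatter of compound 1, since a single pair cannot show how far this position tolerates change. The oxime of compound 2 also remains unresolved: it comes together with a 2-chlorobenzyl group, and no pair shown separates the two.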